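The source may hold more compounds than are shown below. What is called first, only, known or untested is meant among the compounds shown, and "the series" means these compounds.

Compound 3 `Cc1cccc(N(C)CC2CCC/C(=C\c3ccccc3)C2=O)c1` gives 76.7% in a functional assay on the whole organism (strain Kunming) for inhibition, with Mus musculus as the target, in the writhing test, with stated times of 1 h and 15 min, at a dose of 200 mg/kg by the oral route (a lower number here means less inhibition, a higher number more inhibition at the dose given (going by the name of the read-out)), the lowest of the three numbers shown, though its gaps to compound 2 `Cc1ccc(N(C)CC2CCC/C(=C\c3ccccc3)C2=O)cc1`, which gives 81%, and to compound 1 `Cc1ccc(NCC2CCC/C(=C\c3ccccc3)C2=O)cc1`, which gives 82.8%, stay within the scatter. Compound 4 `Cc1cccc(N(C)CC2CCC/C(=C\c3ccc(S(C)(=O)=O)cc3)C2=O)c1` differs from compound 3 by methylsulfonyl in place of hydrogen on an aromatic carbon. Neither measured step touches that ring: a number 1.8 percentage points lower from compound 1 to compound 2 (within the scatter) and a number 4.3 percentage points lower from compound 2 to compound 3 (within the scatter) concern the amine nitrogen, and each lies within the scatter, so they offer no direct guide to a change on the six-membered aromatic ring of carbon only. No step beyond the scatter in this assay is therefore expected, a number 1.7 percentage points lower from compound 3 to compound 4 (within the scatter). Compound 4 is estimated at 75%, with a range from 55% to 90%.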

Compound 4, a percentage reported as inhibition, in the whole organism at one dose (the size of the read-out at that dose, not a potency): 72.8%
Estimate against measurement, compound 4: 2.2 percentage points above; measured number inside the range.
By their numbers in this assay, from the lowest: compounds 4, 3, 2 and 1 (each within the scatter of the next).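

Within the data shown here, the step of a number 3.9 percentage points lower from compound 3 to compound 4 (within the scatter) is the first reading on the six-membered aromatic ring of carbon only, and it shows that this aromatic carbon, para to a large group, can carry methylsulfonyl in this assay without a step beyond the scatter. Nothing measured here offers an explanation for this result. The compounds shown leave open whether an amine or a carboxylic acid on the same carbon would also stay within the scatter. They also leave open how methylsulfonyl would read with the 4-methylphenyl group of compound 2.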